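The source may report more compounds than this note shows. Statements on the series, on what has been measured and on what is new or still open speak of the compounds shown alone.

Compound 1 `COc1ccc(-c2noc(-c3ccccc3)n2)cc1OC1CCCC1` is one of two measured members of this small set. In a functional assay on HCT-116 cells (Homo sapiens) for antiproliferative activity, read by MTT assay, with a stated time of 24 h (a lower number here means a stronger inhibitor, a higher number a weaker inhibitor), compound 1 gives only a limit, > 1000000 nM, and no number. Compound 2 `COc1ccc(-c2noc(-c3ccc(F)cc3)n2)cc1O` likewise gives only a limit in this assay, namely > 1000000 nM. Compound 1 thus stands where every value in this assay stands, since (the limit of > 1000000 nM in this assay, at which 2 of the 2 values shown sit). Compound 3 `COc1ccc(-c2noc(-c3ccc(Cl)cc3)n2)cc1OC1CCCC1` differs from compound 1 by a single change: chloro in place of hydrogen on an aromatic carbon. Within the data shown here, no step between measured compounds exists to guide the size of that change, and both known values sit at the limit rather than at a number. Compound 3 is therefore expected to show no change beyond the scatter in this assay, and the expected step is a number no higher from compound 1 to compound 3 (the limit leaves the size open). The estimate for compound 3 in this assay is 1000000 nM, within a range from 200000 nM to 5000000 nM, most likely again returned only as a limit.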

Compound 3, half-maximal inhibitory concentration: > 1000000 nM
Compound 3: a limit, no number; the forecaster's own chance of this, stated with the estimate: 85%; the middle value sits exactly at the limit.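

Compound 1 and compound 3 both give only a limit in this assay, so no step can be read for chloro in place of hydrogen on an aromatic carbon: the limit of > 1000000 nM in this assay, at which 3 of the 3 values shown sit.

The compounds shown leave open what change to the shared core, if any, would yield a number rather than a limit in this assay.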